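A few compounds are considered here, and "the series" means these few. Any claim that something is new, unique, unknown or untested is made for them only; others in the source may bear on it.

In a functional assay on HUVEC cells (Homo sapiens) for antiproliferative activity, read by MTT assay, with a stated time of 24 h (a lower number here means a stronger inhibitor, a higher number a weaker inhibitor), compound 2 `COc1cccc(C(=O)Oc2ccc3c(=O)c(-c4cc(OC)c(OC)cc4OC)coc3c2)c1` gives only > 10000 nM as a limit of the assay, not a number. Compound 3 `COc1cc(OC)c(-c2coc3cc(OCc4ccc(Br)cc4)ccc3c2=O)cc1OC` likewise gives > 10000 nM as a limit of the assay. Compound 1 `COc1cc(OC)c(-c2coc3cc(OCC=C(C)C)ccc3c2=O)cc1OC` alone returns a true number, with 3800 nM as its value.

Compound 4 `COc1cc(OC)c(-c2coc3cc(OCc4ccc(C#N)cc4)ccc3c2=O)cc1OC` has 4-cyanobenzyl in place of (3-methoxyphenyl)carbonyl on an oxygen on an aromatic ring and so carries a benzyl group on that oxygen, as compound 3 does.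

Going by the values given here, two measured steps bear on this change. As far as these compounds go, both an at least 2.6-fold higher number from compound 1 to compound 2 (0.42 log units; beyond the scatter) and an at least 2.6-fold higher number from compound 1 to compound 3 (0.42 log units; beyond the scatter) run toward weaker inhibition, and both end at the limit of > 10000 nM in this assay, at which 2 of the 3 values shown sit, so their true size stays open. The remaining step that the two limits leave unreadable from compound 2 to compound 3 offers nothing to scale from. Among the compounds with values here, the 4-bromobenzyl of compound 3 is the closest precedent, and compound 3 sits at > 10000 nM as a limit of the assay.

No clear step in either direction is therefore expected in this assay and a further limit is quite possible. The estimate means an at least 1.1-fold lower number from compound 2 to compound 4 (0.04 log units; that floor lies within the scatter) as the expected step. For compound 4 the estimated value is 9000 nM with an expected range of 2500 nM to 30000 nM overall.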

Compound 4, half-maximal inhibitory concentration: > 10000 nM
Compound 4: no number, only a limit (the forecaster's own chance of this, stated with the estimate: 55%); middle value at least 1.1-fold (0.04 log units) from the limit.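

Measured against the 3-methylbut-2-en-1-yl group, the 4-cyanobenzyl group on this oxygen on an aromatic ring gives in this assay an at least 2.6-fold higher number from compound 1 to compound 4 (0.42 log units; beyond the scatter). The loss seen with the 4-bromobenzyl group is therefore not confined to the bromo compound: with cyano in place of bromo on an aromatic carbon, no readable number returns, and all three replacements of the 3-methylbut-2-en-1-yl group shown now end without one. The steps among compound 2, compound 3 and compound 4 cannot be read, so no order among these groups can be drawn, since all three compounds stand at the same limit of the assay: the limit of > 10000 nM in this assay, at which 3 of the 4 values shown sit.

As far as these compounds go, how far the true values of compound 2, compound 3 and compound 4 lie past that limit remains open, and so does any real difference between cyano and bromo. Also open, from the compounds shown here alone, is whether the number of compound 1 depends on the double bond of its chain, as a saturated 3-methylbutyl group on the same oxygen would show, and whether a short chain ending in an amine or a carboxylic acid would give a readable number there.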